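The source may report more compounds than this note shows. Statements on the series, on what has been measured and on what is new or still open speak of the compounds shown alone.

Measured so far:
compound 1 `Fc1ccc2nc(NCCCCN3CCN(c4cccc(Cl)c4Cl)CC3)nc(NCc3ccco3)c2c1` — 520 nM
compound 2 `Cc1cccc(N2CCN(CCCNc3nc(NCc4ccco4)c4cc(F)ccc4n3)CC2)c1C` — 1140 nM

In a functional assay on HCT-116 cells (Homo sapiens) for cytotoxicity, read by MTT assay, with a stated time of 2 days (a lower number here means a stronger inhibitor, a higher number a weaker inhibitor), compound 1 gives 520 nM, the lowest of the two numbers shown. Compound 2 gives 1140 nM, a higher number, and this gap lies beyond the usual scatter. Compound 2 also carries a 2,3-dimethylphenyl group and a shorter chain than compound 1, so the two measured compounds differ in more than one place and no single step can be read from them.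

Compound 3 `Cc1cccc(N2CCN(CCCCNc3nc(NCc4ccco4)c4cc(F)ccc4n3)CC2)c1C` has not yet been measured. It differs from compound 1 in one place: 2,3-dimethylphenyl in place of 2,3-dichlorophenyl on an amine nitrogen in a ring. Among the measured compounds shown here, with no step between measured compounds to lean on, the expectation rests only on compound 2, whose 1140 nM pairs the 2,3-dimethylphenyl group with a higher number than compound 1. For compound 3 a small step toward a weaker result, near the edge of the scatter, is expected, a 1.5-fold higher number from compound 1 to compound 3 (0.19 log units; within the scatter). Compound 3 is therefore estimated at 800 nM, within a range of 350 nM to 1800 nM.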

Compound 3, half-maximal inhibitory concentration: 820 nM
The estimate for compound 3 lay 1.0-fold (0.01 log units) below the measured number; measured number inside the range.
By their numbers in this assay, from the lowest: compounds 1, 3 and 2 (each within the scatter of the next, the first and the last beyond it).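

Among the compounds shown here, putting 2,3-dimethylphenyl in place of 2,3-dichlorophenyl on the amine nitrogen in the ring gives a 1.6-fold higher number from compound 1 to compound 3 (0.20 log units; within the scatter) and, measured in this assay with the rest of the molecule unchanged, this is the first reading of this one change. The two earlier compounds differed in more than one place, so they could not isolate it. The step lies within the usual scatter, so these two groups, which share the same heavy-atom count, cannot be told apart by this measurement, and nothing available explains the result.

As far as these compounds go, whether a methoxy group or a trifluoromethyl group on the phenyl ring would shift the number beyond the scatter remains open. Also open, from the compounds shown here alone, is whether the same exchange would give a similar step on a longer chain.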